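This account rests on a few compounds, and the source may have more. Where it says the series, first, only, none or still open, it means among the compounds named here.

In an assay on membranes from Cerebral cortex for displacement of a labelled ligand from Neuronal acetylcholine receptor; alpha4/beta2 (Rattus norvegicus), with a stated time of 5 min (a higher number here means a weaker inhibitor, a lower number a stronger inhibitor), compound 2, with the structure `CN1CCC[C@H]1[C@@H]1COc2cc([N+](=O)[O-])ccc2O1`, gives 46000 nM, the lower of the two numbers recorded. Compound 1, with the structure `CN1CCC[C@H]1[C@H]1COc2cc(N)ccc2O1`, gives 74000 nM in this assay, and the gap between compound 1 and compound 2 lies within the scatter, so the two cannot be told apart on these figures. Compound 3, with the structure `CN1CCC[C@H]1[C@H]1COc2cc([N+](=O)[O-])ccc2O1`, has not yet been measured. It is related to compound 2 in one respect only: the two compounds have the same atoms and bonds and differ only in configuration as drawn: 1 of 2 stereo elements differ; a stereocentre at a saturated ring carbon is drawn R in compound 2 and S in compound 3. Among the measured compounds shown here, no step between measured compounds involving a change of this kind exists, so the direction and size of the effect are unknown. The expectation for compound 3 therefore rests on compound 2, whose value of 46000 nM is taken as the starting point, and the step from compound 2 to compound 3 is expected to be a 1.3-fold higher number from compound 2 to compound 3 (0.12 log units; within the scatter), not clearly beyond the scatter. Compound 3 is accordingly estimated at 60000 nM, with a range from 15000 nM to 250000 nM.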

Compound 3, inhibition constant: > 100000 nM
Compound 3 ended at the assay's limit; the forecaster's own chance of this, stated with the estimate: 20%; middle value at least 1.6-fold (0.22 log units) away from the limit.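

Among the compounds shown here, compounds 1 and 2 differed in two places and could not separate the effect of the stereocentre from that of the ring substituent, whereas this pair gives a first reading on configuration alone, an at least 2.1-fold higher number from compound 2 to compound 3 (0.33 log units; beyond the scatter), and that step can be tied to the saturated ring carbon: the fact that compounds 2 and 3 differ only in the configuration as drawn. In this assay, compound 3 gives > 100000 nM, which is a limit of the assay and not a number, so the step is only a floor: the limit of > 100000 nM in this assay, at which 1 of the 3 values shown sits. The exchange of amino for nitro with the configuration held gives an at least 1.3-fold higher number from compound 1 to compound 3 (0.13 log units; that floor lies within the scatter), and this cannot be read as a real change.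

The compounds shown leave open whether the stereocentre counts in the same way when amino replaces nitro. They also leave open how a hydroxyl, a methoxy or a nitrile on that aromatic carbon would fare.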